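The source may report more compounds than this note shows. Statements on the series, on what has been measured and on what is new or still open speak of the compounds shown alone.

Three compounds share a common core and differ in the group on the sulfonamide nitrogen. Compound 1 `O=C1NCCN1c1ccc(S(=O)(=O)Nc2ccc(F)c(F)c2)cc1` gives 220 nM in a functional assay on M21 cells (Homo sapiens) for antiproliferative activity, read by sulforhodamine B assay, with a stated time of 48 h (on this read-out higher numbers stand for weaker inhibition and lower numbers for stronger inhibition), and compound 2 `O=C1NCCN1c1ccc(S(=O)(=O)Nc2ccc(I)cc2)cc1` gives 260 nM; the step of a 1.2-fold higher number from compound 1 to compound 2 (0.07 log units; within the scatter) lies within the scatter. Compound 3 `O=C1NCCN1c1ccc(S(=O)(=O)Nc2cccc(Oc3ccccc3)c2)cc1` gives 83 nM, the lowest of the three, separated from both others by more than the scatter. Compound 4 `COc1cccc(NS(=O)(=O)c2ccc(N3CCNC3=O)cc2)c1` differs from compound 3 by methyl in place of phenyl on an oxygen on an aromatic ring, phenoxy to methoxy. Going by the values given here, no measured step touches the oxygen-borne group. Compound 1 at 220 nM and compound 2 at 260 nM, which lack the phenoxy group, both return higher numbers than compound 3, so a modest rise is expected for compound 4, about a 2.2-fold higher number from compound 3 to compound 4 (0.34 log units; beyond the scatter). Compound 4 is therefore estimated at 180 nM, ranging from 70 nM to 450 nM.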

Compound 4, half-maximal inhibitory concentration: 65 nM
Estimate against measurement, compound 4: 2.8-fold (0.44 log units) above; measured number outside the range, below it.
By their numbers in this assay, from the lowest: compounds 4 and 3 (each within the scatter of the next); then compounds 1 and 2 (each within the scatter of the next).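

In this assay, a 1.3-fold lower number from compound 3 to compound 4 (0.11 log units; within the scatter) shows that phenyl and methyl on this oxygen cannot be told apart, so the low number of compound 3 does not depend on the phenyl ring. The 3-methoxyphenyl group on the sulfonamide nitrogen still separates from the other two groups, with a 4.0-fold lower number from compound 2 to compound 4 (0.60 log units; beyond the scatter) and a 3.4-fold lower number from compound 1 to compound 4 (0.53 log units; beyond the scatter), both beyond the scatter. Nothing available explains this result. The compounds shown leave open how a longer chain or an amine carried on that oxygen would read in this assay.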